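Methoxy for tert-butyl on the benzyl arm of compound 2

A few compounds are considered here, and "the series" means these few. Any claim that something is new, unique, unknown or untested is made for them only; others in the source may bear on it.

Measured so far:
Compound 1 `O=S(=O)(NCCCNCc1ccccc1Cl)c1cc(C(F)(F)F)cc(C(F)(F)F)c1`: 13000 nM
Compound 2 `CC(C)(C)c1ccc(CNCCCNS(=O)(=O)c2cc(C(F)(F)F)cc(C(F)(F)F)c2)cc1`: 2100 nM
Compound 3 `O=S(=O)(NCCCNCc1cccc2ccccc12)c1cc(C(F)(F)F)cc(C(F)(F)F)c1`: 2700 nM

In a functional assay on Capan-2 cells (Homo sapiens) for inhibition, read by MTT assay, with a stated time of 72 h (a higher number here means a weaker inhibitor of growth, a lower number a stronger inhibitor of growth), compound 2 holds the lowest number of the three, though compound 3 sits within the scatter of it, while compound 1 lies well apart, as the step of a 6.2-fold lower number from compound 1 to compound 2 (0.79 log units; beyond the scatter) shows. Compound 4 `COc1ccc(CNCCCNS(=O)(=O)c2cc(C(F)(F)F)cc(C(F)(F)F)c2)cc1` differs from compound 2 as follows: methoxy in place of tert-butyl on an aromatic carbon. Among the compounds with values here, no measured step exchanges a group on this aromatic carbon, so the two measured steps, a 6.2-fold lower number from compound 1 to compound 2 (0.79 log units; beyond the scatter) and a 4.8-fold lower number from compound 1 to compound 3 (0.68 log units; beyond the scatter), bear on it only loosely; both show that the benzyl group matters to this assay. A modest rise in the number is therefore expected, a 2.4-fold higher number from compound 2 to compound 4 (0.38 log units; beyond the scatter). Compound 4 is estimated at 5000 nM, within 2000 nM to 15000 nM.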

Compound 4, concentration for 50% growth inhibition: 2400 nM
Estimate against measurement, compound 4: 2.1-fold (0.32 log units) above; measured number inside the range.
By their numbers in this assay, from the lowest: compounds 2, 4 and 3 (each within the scatter of the next); then compound 1.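

In this assay, tert-butyl and methoxy on this aromatic carbon cannot be told apart, with a 1.1-fold higher number from compound 2 to compound 4 (0.06 log units; within the scatter), even though methoxy has fewer heavy atoms and adds a hydrogen-bond acceptor. The 4-methoxyphenyl arm also matches the naphthalen-1-yl arm, with a 1.1-fold lower number from compound 3 to compound 4 (0.05 log units; within the scatter), while a 5.4-fold lower number from compound 1 to compound 4 (0.73 log units; beyond the scatter) leaves compound 1 alone, apart from compounds 2, 3 and 4. No evidence is available to explain this tolerance.

The compounds shown leave open whether a 4-chlorophenyl arm would stay with compounds 2, 3 and 4 or with compound 1. They also leave open whether a carboxylic acid or an amine on this aromatic carbon would be tolerated as well.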